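Trimming the Side Chain of a Benzylated Sugar Scaffold

The source may hold more compounds than are shown below. What is called first, only, known or untested is meant among the compounds shown, and "the series" means these compounds.

The series gathers four compounds that share a core carrying three benzyl-protected oxygens and a free hydroxyl. Compound 1 `C#CC[C@@H]1O[C@H](COCc2ccccc2)[C@@H](OCc2ccccc2)[C@H](OCc2ccccc2)[C@H]1O` was reported in a functional assay on HL-60 cells (Homo sapiens) for antiproliferative activity, read by MTT assay (a higher number here means a weaker inhibitor, a lower number a stronger inhibitor), as "not active" (no number reported), and compound 2 `CC(C)(C)C[C@@H]1O[C@H](COCc2ccccc2)[C@@H](OCc2ccccc2)[C@H](OCc2ccccc2)[C@H]1O` was likewise reported in this assay as "not active" (no number reported), with no number given for either. Among the measured compounds shown here, compound 3 `O[C@@H]1[C@@H](OCc2ccccc2)[C@H](OCc2ccccc2)[C@@H](COCc2ccccc2)O[C@H]1Cc1ccccc1` is the only member with a measured value: in this assay compound 3 gives 8700 nM, which places it as the sole quantified entry, with the two others falling short of any reported number.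

Compound 4 `CC[C@@H]1O[C@H](COCc2ccccc2)[C@@H](OCc2ccccc2)[C@H](OCc2ccccc2)[C@H]1O` differs from compound 3 by methyl in place of phenyl on a saturated chain carbon bound to a saturated ring carbon. For the measured compounds named here, no step between two measured compounds is available to guide this change, and the two inactive neighbours, compound 1 and compound 2, show that altering this chain can remove measurable activity altogether. Compound 4 is therefore expected to be at best comparable to compound 3 and more likely weaker, with a step of a 2.9-fold higher number from compound 3 to compound 4 (0.46 log units; beyond the scatter) in this assay of modest size. Compound 4 is estimated at 25000 nM, within a range from 8000 nM to 80000 nM.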

Compound 4, half-maximal inhibitory concentration: 8200 nM
Compound 4: the middle estimate sits 3.0-fold (0.48 log units) above what was measured; the measured number falls inside the stated range.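

In this assay, the swap of benzyl for ethyl gives a 1.1-fold lower number from compound 3 to compound 4 (0.03 log units; within the scatter), so on a saturated chain carbon bound to a saturated ring carbon the phenyl can be lost without a change that stands out from the scatter. The aromatic ring of this side chain is therefore not required for a measurable value, which compound 3 alone could not show, and the series now holds two measured compounds beside compound 1 at "not active" (no number reported) and compound 2 at "not active" (no number reported). No available evidence accounts for this flat step or for the gap between the measured and the inactive compounds.

The compounds shown leave open how an amine or a carboxylic acid at the end of a longer chain would read in this place. They also leave open whether a plain methyl here would keep a measurable value.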